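The source may report more compounds than this note shows. Statements on the series, on what has been measured and on what is new or still open speak of the compounds shown alone.

Measured so far:

Compound 1, `CCOc1ccc(-c2cccc(S(=O)(=O)N(C)C)c2)cc1`, gives 110000 nM in an assay on COS-7 cells for inhibition of patatin-like phospholipase domain-containing protein 2 (Mus musculus); a higher number here means a weaker inhibitor, a lower number a stronger inhibitor.
Compound 2, `CCOc1ccc(-c2ccccc2)cc1`, gives only a limit in this assay, > 200000 nM.
Compound 3, `CCOc1ccc(-c2cccc(C(=O)O)c2)cc1`, likewise gives only a limit in this assay, > 200000 nM.

Compound 3 thus stands at the edge of what this assay can report: the limit of > 200000 nM in this assay, at which 2 of the 3 values shown sit. The change to compound 4, `CCOc1ccc(-c2cccc(C(=O)OCCOCCOC)c2)cc1`, is 2-(2-methoxyethoxy)ethyl in place of hydrogen on an oxygen next to a carbonyl group, so the free acid becomes an ester carrying a short chain.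

Among the compounds with values here, two measured steps touch compound 3. Replacing dimethylsulfamoyl by carboxy gave an at least 1.8-fold higher number from compound 1 to compound 3 (0.25 log units; that floor lies within the scatter), and replacing hydrogen by carboxy gave a step that the two limits leave unreadable from compound 2 to compound 3. Within the data shown here, neither step involves an ester, so no measured step speaks directly to the change at hand; the nearest comparison is that the dimethylsulfamoyl compound 1 is the only one with a readable number.

The step is expected to be an at least 1.1-fold lower number from compound 3 to compound 4 (0.04 log units; that floor lies within the scatter). Compound 4 is therefore estimated at 180000 nM, with a range from 70000 nM to 400000 nM, and a readable number is far from assured.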

Compound 4, half-maximal inhibitory concentration: > 200000 nM
Compound 4 was reported as a limit; the forecaster's own chance of this, stated with the estimate: 55%; at least 1.1-fold (0.04 log units) between middle value and limit.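

In this assay compound 4 gives > 200000 nM, a limit and not a number. Within the data shown here, compound 3 is also reported only as a limit, so no step between compound 3 and compound 4 can be read. As far as these compounds go, whether the 2-(2-methoxyethoxy)ethyl ester changes inhibition at all remains open.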